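Replacing the pyrrolidine on the amide with an arylsulfonyl group

A few compounds are considered here, and "the series" means these few. Any claim that something is new, unique, unknown or untested is made for them only; others in the source may bear on it.

For the measured compounds named here, compound 1 `Cc1cc(C)cc(S(=O)(=O)c2c(C(=O)N[C@H]3CCNC3)[nH]c3ccc(Cl)cc23)c1` is the only member of the set with a numerical reading in an ADME assay on MT4 cells (Homo sapiens) for cytotoxicity, read by MTT assay, with a stated time of 5 days; on this read-out higher numbers stand for lower toxicity in this test and lower numbers for higher toxicity in this test: compound 1 gives 10000 nM. Compound 2 `Cc1cc(C)cc(S(=O)(=O)c2c(C(=O)N[C@H]3CCN(Cc4ccccc4C#N)C3)[nH]c3ccc(Cl)cc23)c1` reaches only a limit of the test, > 228000 nM. Compound 3 `Cc1cc(C)cc(S(=O)(=O)c2c(C(=O)NC3CN(Cc4ccccc4C#N)C3)[nH]c3ccc(Cl)cc23)c1` likewise sits at a limit, > 234000 nM. Going by the values given here, the one counted step, an at least 22-fold higher number from compound 1 to compound 2 (1.35 log units; beyond the scatter), is 2-cyanobenzyl in place of hydrogen on an amine nitrogen in a ring, and its size rests on the limit of > 228000 nM in this assay, at which 1 of the 3 values shown sits, rather than on a second number.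

Compound 4 `Cc1cc(C)cc(S(=O)(=O)c2c(C(=O)NS(=O)(=O)c3ccc(F)cc3)[nH]c3ccc(Cl)cc23)c1` differs from compound 1 by (4-fluorophenyl)sulfonyl in place of pyrrolidin-3-yl on an amide-type nitrogen. Among the compounds with values here, no measured step touches this position directly; the step from compound 1 to compound 2 is the only movement available, and it shows that a change at the pyrrolidine nitrogen carries the reading to the upper edge of the test. The expectation for compound 4 is therefore a higher number in this assay, an 8.0-fold higher number from compound 1 to compound 4 (0.90 log units; beyond the scatter), with a real chance that only a limit is returned. Compound 4 is estimated at 80000 nM (range 15000 nM to 300000 nM).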

Compound 4, half-maximal cytotoxic concentration: > 252000 nM
Compound 4: no number, only a limit; the forecaster's own chance of this, stated with the estimate: 45%; middle value at least 3.1-fold (0.49 log units) from the limit.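

Change on the amide-type nitrogen itself, and not only on the ring amine nitrogen, moves the reading in this assay: (4-fluorophenyl)sulfonyl in place of pyrrolidin-3-yl gives an at least 25-fold higher number from compound 1 to compound 4 (1.40 log units; beyond the scatter). Compound 4 returns only a limit of the test, not a number: the limit of > 252000 nM in this assay, at which 1 of the 4 values shown sits.

For the compounds shown here, compound 1, the only member that keeps the unsubstituted ring amine nitrogen, is also the only one with a numerical reading, while compound 2, compound 3 and compound 4 all end at limits.

These limits cannot be ranked against one another, so the true size of each change remains unread. On these data alone, it also remains open whether the shift follows the removal of the ring amine or the entry of the sulfonyl group, a question that an open-chain aminoethyl group or a methylsulfonyl group on the amide-type nitrogen would address.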